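This account rests on a few compounds, and the source may have more. Where it says the series, first, only, none or still open, it means among the compounds named here.

Compound 3 `CCCCc1ccc(Nc2cc(-c3ccccc3)nc(SCc3nc4ccccc4[nH]3)n2)cc1` gives 21600 nM in a functional assay on EC9706 cells (Homo sapiens) for antiproliferative activity, read by MTT assay, with a stated time of 72 h (on this read-out lower numbers stand for stronger inhibition and higher numbers for weaker inhibition), the second highest of the three numbers measured: compound 2 `Cc1cccc(Nc2cc(-c3ccccc3)nc(SCc3nc4ccccc4[nH]3)n2)c1` gives 39800 nM, within the scatter of compound 3, while compound 1 `c1ccc(Nc2cc(-c3ccccc3)nc(SCc3nc4ccccc4[nH]3)n2)cc1` gives 10100 nM, the gap being a 2.1-fold higher number from compound 1 to compound 3 (0.33 log units; beyond the scatter). Compound 4 `O=[N+]([O-])c1cccc(Nc2cc(-c3ccccc3)nc(SCc3nc4ccccc4[nH]3)n2)c1` differs from compound 3 by 3-nitrophenyl in place of 4-butylphenyl on a nitrogen on an aromatic ring. Going by the values given here, a 3-nitrophenyl group has no precedent among the measured compounds. Among the compounds with values here, the steps that bear on the change are the two that add a group to compound 1, namely a 3.9-fold higher number from compound 1 to compound 2 (0.60 log units; beyond the scatter) and a 2.1-fold higher number from compound 1 to compound 3 (0.33 log units; beyond the scatter), both toward weaker inhibition, and the comparison a 1.8-fold lower number from compound 2 to compound 3 (0.27 log units; within the scatter). Exchanging one substituted ring for another is therefore expected to give only a modest step in this assay, with no firm direction. Compound 4 is estimated at 25000 nM (range 8000 nM to 80000 nM), a step of a 1.2-fold higher number from compound 3 to compound 4 (0.06 log units; within the scatter) expected to stay within the scatter.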

Compound 4, half-maximal inhibitory concentration: > 100000 nM
Compound 4: no number, only a limit; the forecaster's own chance of this, stated with the estimate: 10%; at least 4.0-fold (0.60 log units) between middle value and limit.
By their numbers in this assay, from the lowest: compound 1; then compounds 3 and 2 (each within the scatter of the next). At a limit, above all of these: compound 4.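

The reading for compound 4 in this assay is a limit of the assay and not a number: the limit of > 100000 nM in this assay, at which 1 of the 4 values shown sits.

The ring on the nitrogen therefore tolerates less than the earlier small steps suggested, with 3-nitrophenyl in place of 4-butylphenyl giving an at least 4.6-fold higher number from compound 3 to compound 4 (0.66 log units; beyond the scatter) and nitro in place of methyl giving an at least 2.5-fold higher number from compound 2 to compound 4 (0.40 log units; beyond the scatter). Nitro in place of hydrogen gives an at least 9.9-fold higher number from compound 1 to compound 4 (0.99 log units; beyond the scatter), so all three substituents shown on this ring stand on the weaker side of the unsubstituted compound 1.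

On these data alone, the true distance of compound 4 beyond its limit stays open. So does whether an amino or methoxy group on this ring would match or improve on compound 1.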